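Methyl to hydrogen on the core of compound 2

The source may hold more compounds than are shown below. What is called first, only, known or untested is meant among the compounds shown, and "the series" means these compounds.

Within the data shown here, compound 2 `Cc1cccc(/C(N)=N/NC(=S)N2CCSCC2)n1` stands highest of the two numbers so far in a functional assay on MCF7 cells (Homo sapiens) for cytotoxicity, read by MTT assay, with a stated time of 72 h, tested at 10 uM (a higher number here means more inhibition of growth at the concentration tested, a lower number less inhibition of growth), where compound 2 gives 22.5%. Compound 1 `Cc1ccnc(/C(N)=N/NC(=S)N2CCOCC2)c1` in this assay gives 6.86%, a number beyond the scatter below that of compound 2; the two structures differ in more than one place, so the gap is not tied to any single change. Compound 3 `N/C(=N\NC(=S)N1CCSCC1)c1ccccn1` carries hydrogen in place of methyl on an aromatic carbon, hydrogen in place of methyl on an aromatic carbon. Among the measured compounds shown here, no measured step of this kind exists here, so only a small step in this assay is expected, if any, downward. Compound 3 is estimated at 18%, between 5% and 35%, meaning an expected step of a number 4.5 percentage points lower from compound 2 to compound 3 (within the scatter).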

Compound 3, percent growth inhibition at one concentration: 54.3%
For compound 3 the middle estimate is 36.3 percentage points below the measured one; the measured number lies above the stated range.
By their numbers in this assay, from the lowest: compound 1; then compound 2; then compound 3.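

In this assay, hydrogen in place of methyl on an aromatic carbon next to the ring nitrogen gives a large change (a number 31.8 percentage points higher from compound 2 to compound 3 (beyond the scatter)). Among these compounds, this is the first comparison that differs in one place, and it shows that this position is not indifferent to substitution, with the methyl the less favourable of the two groups. Nothing at hand speaks to the cause of this step.

On these data alone, whether a chlorine atom, a methoxy group or an amine on this carbon would stand nearer compound 2 or compound 3 remains open. Also open, as far as these compounds go, is whether the same change would give a similar step on the core of compound 1.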